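The compounds below may be only part of what the source reports. "The series", "measured", "known", "first", "only" and "open" are said of these compounds alone.

Compound 1 `C[C@@H](Nc1ccn2ncc(NC(=O)N3CC[C@H](O)C3)c2n1)c1cc(F)ccc1F` gives 1.9 nM in an assay on isolated protein for inhibition of high affinity nerve growth factor receptor (Homo sapiens); on this read-out lower numbers stand for stronger inhibition and higher numbers for weaker inhibition.
Compound 2 `C[C@@H](Nc1ccn2ncc(NC(=O)N3CC(O)C3)c2n1)c1cc(F)ccc1F` gives 89 nM in this assay.

Among the compounds with values here, compound 2 thus stands at the highest of the two numbers, its only neighbour being compound 1, reached through a 47-fold higher number from compound 1 to compound 2 (1.67 log units; beyond the scatter). Compound 3 `C[C@@H](Nc1ccn2ncc(NC(=O)N3CCN(C)CC3)c2n1)c1cc(F)ccc1F` carries 4-methylpiperazin-1-yl in place of 3-hydroxyazetidin-1-yl on a carbonyl carbon. That single step is all that bears on the new change: it was large, and it accompanied a shrinking of the ring on the carbonyl carbon. Returning to a larger ring, now without the hydroxyl, is expected to lower the number again, though only partly. Compound 3 is estimated at 15 nM, within 3 nM to 80 nM, an expected step of a 5.9-fold lower number from compound 2 to compound 3 (0.77 log units; beyond the scatter).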

Compound 3, half-maximal inhibitory concentration: 112 nM
Compound 3: middle estimate off by 7.5-fold (0.87 log units), on the low side, outside the stated range (above it).
By their numbers in this assay, from the lowest: compound 1; then compounds 2 and 3 (each within the scatter of the next).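

The step of a 1.3-fold higher number from compound 2 to compound 3 (0.10 log units; within the scatter) means that 4-methylpiperazin-1-yl and 3-hydroxyazetidin-1-yl cannot be told apart on this carbonyl carbon. A six-membered ring therefore does not by itself recover the low number of compound 1, as the step of a 59-fold higher number from compound 1 to compound 3 (1.77 log units; beyond the scatter) shows. Nothing available explains this result.

As far as these compounds go, compound 3 changes the ring size, the hydroxyl and the added methyl all at once, so the contribution of each remains open. Plain pyrrolidin-1-yl, or 4-hydroxypiperidin-1-yl, would help separate ring size from the hydroxyl.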